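The compounds below may be only part of what the source reports. "The series", "measured", "known", "first", "only" and "open" are said of these compounds alone.

Notes on the series. Among the measured compounds shown here, compound 1 `COc1ccc2[nH]c3c(c2c1)CCNC31CCN(Cc2ccc(F)c(Cl)c2F)CC1` gives 4500 nM in an assay on FRT cells for positive allosteric modulation of Cystic fibrosis transmembrane conductance regulator variant N1303K (Homo sapiens), in the presence of a further agent that is not named here (a lower number here means that less compound is needed, a higher number that more compound is needed for the effect), the highest of the three numbers measured so far. Compound 3 `COc1ccc2[nH]c3c(c2c1)CCNC31CCN(Cc2ccc(F)c(F)c2F)CC1` gives 4100 nM and compound 2 `COc1ccc2[nH]c3c(c2c1)CCNC31CCN(Cc2c(F)c(F)c(F)c(F)c2F)CC1` gives 2100 nM; the step of a 1.1-fold lower number from compound 1 to compound 3 (0.04 log units; within the scatter) lies within the scatter, while the gap between compound 1 and compound 2 lies beyond it. The next compound, compound 4 `COc1ccc2[nH]c3c(c2c1)CCNC31CCN(Cc2cc(F)c(F)cc2F)CC1`, differs from compound 1 by 2,4,5-trifluorophenyl in place of 3-chloro-2,4-difluorophenyl on a saturated chain carbon bound to an amine nitrogen in a ring. For the measured compounds named here, the only measured single-place step that bears on this change is a 1.1-fold lower number from compound 1 to compound 3 (0.04 log units; within the scatter), a halogen swap on the same aromatic ring that left the number essentially where it was. Going by the values given here, compound 2 shows that a ring carrying only fluorine can read lower, but no single-place step links it to compound 1. For compound 4 the expected outcome is therefore a small movement, a 1.2-fold lower number from compound 1 to compound 4 (0.07 log units; within the scatter), with a lean towards a slightly lower number and no confidence that it clears the scatter. For compound 4 the estimate is 3800 nM, within a range of 1800 nM to 8000 nM.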

Compound 4, half-maximal effective concentration: 600 nM
Beside the measured number, compound 4's estimate is 6.3-fold (0.80 log units) above it; measured number outside the range, below it.
By their numbers in this assay, from the lowest: compound 4; then compounds 2, 3 and 1 (each within the scatter of the next, the first and the last beyond it).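

The aryl group on a saturated chain carbon bound to an amine nitrogen in a ring is more sensitive than the halogen swap alone indicated: in this assay there is a 6.8-fold lower number from compound 3 to compound 4 (0.83 log units; beyond the scatter), and both compounds carry three fluorines on the ring, so rearranging them is enough to move the number beyond the scatter. The change from 3-chloro-2,4-difluorophenyl, a 7.5-fold lower number from compound 1 to compound 4 (0.88 log units; beyond the scatter), also lies beyond the scatter, whereas a 1.1-fold lower number from compound 1 to compound 3 (0.04 log units; within the scatter) does not, so compound 4 stands apart from both by its 2,4,5-trifluorophenyl group. Nothing available explains why this arrangement of fluorines reads lower.

Going by these compounds, whether the lower number survives with chloro or methoxy in place of any one fluorine of the 2,4,5-trifluorophenyl group remains open. So does whether it survives a longer chain between that ring and the amine nitrogen.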